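The source may report more compounds than this note shows. Statements on the series, on what has been measured and on what is new or still open speak of the compounds shown alone.

In a functional assay on U-87MG ATCC cells (Homo sapiens) for inhibition (a lower number here means a stronger inhibitor, a higher number a weaker inhibitor), two compounds with a shared core have been measured: compound 1 `COc1cc(/C=C/C(=O)c2cccc(NC(=O)c3c(Cl)cccc3Cl)c2)ccc1O` gives 17.8 ug/mL and compound 2 `COc1cc(/C=C/C(=O)c2cccc(NC(=O)c3cccs3)c2)ccc1O` gives 14.7 ug/mL. For the measured compounds named here, compound 2 therefore stands within the scatter of its only neighbour, and the two cannot be ranked. Compound 3 `COc1cc(/C=C/C(=O)c2cccc(NC(=O)c3cc(Cl)cc(Cl)c3)c2)ccc1O`, not yet measured, carries 3,5-dichlorophenyl in place of thiophen-2-yl on a carbonyl carbon. Going by the values given here, only one measured step bears on this change, and it also exchanges a dichlorophenyl group for thiophen-2-yl at that carbonyl carbon: a 1.2-fold lower number from compound 1 to compound 2 (0.08 log units; within the scatter). Going by that single small step, no change beyond the scatter is expected in this assay, although one pair is thin evidence and 3,5-dichlorophenyl itself is untested. The expected step is a 1.1-fold higher number from compound 2 to compound 3 (0.04 log units; within the scatter). For compound 3 the estimate is 16 ug/mL, with an expected range from 9 ug/mL to 28 ug/mL.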

Compound 3, half-maximal inhibitory concentration: > 50 ug/mL
Compound 3: only a limit was reported; the forecaster's own chance of this, stated with the estimate: 5%; middle value at least 3.1-fold (0.49 log units) away from the limit.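

Compound 3 is reported only as a limit, not as a number: the limit of > 50 ug/mL in this assay, at which 1 of the 3 values shown sits.

Even so, this assay shows that the group on this carbonyl carbon can matter, since 3,5-dichlorophenyl in place of thiophen-2-yl gives an at least 3.4-fold higher number from compound 2 to compound 3 (0.53 log units; beyond the scatter), whereas the earlier pair showed no separable change. The two dichlorophenyl groups also part ways, with an at least 2.8-fold higher number from compound 1 to compound 3 (0.44 log units; beyond the scatter), so having two chlorines on the ring does not by itself fix the result: 2,6-dichlorophenyl and 3,5-dichlorophenyl differ here although each carries the same atoms.

On these data alone, how far compound 3 lies beyond its limit stays unknown, and so does the full size of both steps. As far as these compounds go, it is also open how plain phenyl, 3-chlorophenyl or a ring bearing a carboxylic acid would behave on this carbonyl carbon, and no cause for the change can be drawn from these compounds.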